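Chain lengthening on the inner amino acid unit: next step

The source may hold more compounds than are shown below. What is called first, only, known or untested is meant among the compounds shown, and "the series" means these compounds.

Measured in an assay on isolated protein for inhibition of Lon protease homolog, mitochondrial (Homo sapiens), read by HTRF, with a stated time of 50 min, in the presence of a further agent that is not named here; on this read-out lower numbers stand for stronger inhibition and higher numbers for weaker inhibition:
compound 1 `CC(C)C[C@H](NC(=O)[C@@H](C)NC(=O)c1cnccn1)B(O)O` gives 433 nM
compound 2 `CC[C@@H](NC(=O)c1cnccn1)C(=O)N[C@@H](CC(C)C)B(O)O` gives 408 nM
compound 3 `CCC[C@@H](NC(=O)c1cnccn1)C(=O)N[C@@H](CC(C)C)B(O)O` gives 187 nM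

Compound 3 stands lowest of the three numbers shown in this assay; the nearest is compound 2, separated by a 2.2-fold lower number from compound 2 to compound 3 (0.34 log units; beyond the scatter), and compound 1 lies furthest, separated by a 2.3-fold lower number from compound 1 to compound 3 (0.36 log units; beyond the scatter). A further step, a 1.1-fold lower number from compound 1 to compound 2 (0.03 log units; within the scatter), lies within the scatter.

Compound 4 `CCCC[C@@H](NC(=O)c1cnccn1)C(=O)N[C@@H](CC(C)C)B(O)O` carries the change (methyl in place of hydrogen on a saturated chain carbon, four bonds along the chain from an amide-type nitrogen and a carbonyl carbon). Among the measured compounds shown here, the steps that bear on it are a 2.3-fold lower number from compound 1 to compound 3 (0.36 log units; beyond the scatter) and a 2.2-fold lower number from compound 2 to compound 3 (0.34 log units; beyond the scatter), both modest and both toward a lower number. Compound 4 is therefore expected to show a step of a 1.4-fold lower number from compound 3 to compound 4 (0.16 log units; within the scatter), of similar or smaller size, with a result within the scatter not excluded. Compound 4 is estimated at 130 nM, range 65 nM to 300 nM.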

Compound 4, half-maximal inhibitory concentration: 93 nM
For compound 4 the middle estimate is 1.4-fold (0.15 log units) above the measured one; low and high end bracket the measured number.
By their numbers in this assay, from the lowest: compounds 4 and 3 (each within the scatter of the next); then compounds 2 and 1 (each within the scatter of the next).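

In this assay, the added methyl at this position gives a 2.0-fold lower number from compound 3 to compound 4 (0.30 log units; within the scatter), so this last lengthening does not by itself separate the two compounds. Over the longer span, the steps add up: propyl in place of hydrogen gives a 4.7-fold lower number from compound 1 to compound 4 (0.67 log units; beyond the scatter) and ethyl in place of hydrogen gives a 4.4-fold lower number from compound 2 to compound 4 (0.64 log units; beyond the scatter), both modest. The ethyl change reads alike on two cores: the same change on two cores in this assay, a 2.3-fold lower number (0.36 log units; beyond the scatter) from compound 1 to compound 3 and a 4.4-fold lower number (0.64 log units; beyond the scatter) from compound 2 to compound 4, 1.9-fold (0.28 log units) apart, within the scatter of two such steps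

Open: whether a longer chain such as pentyl extends these steps, and how a chain ending in an amine or a carboxylic acid reads at this position.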